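Compound 3 to compound 4: a larger group on sulfur

A few compounds are considered here, and "the series" means these few. Any claim that something is new, unique, unknown or untested is made for them only; others in the source may bear on it.

- compound 1 `C#CCSc1nc(Sc2nnnn2CCN(C)C)c(C#N)c(-c2ccc(Cl)cc2)n1`: 7340 nM
- compound 2 `C#CCSc1nc(Sc2nccs2)c(C#N)c(-c2ccc(Br)cc2)n1`: 3990 nM
- compound 3 `C#CCSc1nc(Sc2nncs2)c(C#N)c(-c2cc(OC)c(OC)c(OC)c2)n1`: 4660 nM

These three compounds were tested in a functional assay on SMMC-7721 cells (Homo sapiens) for antiproliferative activity, read by MTT assay, with a stated time of 72 h (on this read-out lower numbers stand for stronger inhibition and higher numbers for weaker inhibition), and gave closely grouped results. Compound 3 (4660 nM) lies within the usual scatter of compound 2 (3990 nM) and also within that of compound 1 (7340 nM), so no order can be drawn among them. Going by the values given here, no two of the measured compounds differ in only one place, which leaves no measured step that speaks directly to the next change.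

That change leads to compound 4 `C#CCSc1nc(Sc2nc3ccccc3s2)c(C#N)c(-c2cc(OC)c(OC)c(OC)c2)n1`, which has 1,3-benzothiazol-2-yl in place of 1,3,4-thiadiazol-2-yl on a sulfur. The rest of the structure of compound 3 is kept. Among the compounds with values here, the three measured compounds carry different groups on that sulfur, yet their values stay within the scatter of one another, and that is the only guide available. A shift beyond the scatter is therefore not expected in this assay, and the direction is left open. The expected change is small (a 1.2-fold lower number from compound 3 to compound 4 (0.07 log units; within the scatter)). For compound 4 the estimated value is 4000 nM, with an expected range from 1800 nM to 9000 nM.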

Compound 4, half-maximal inhibitory concentration: > 20000 nM
Compound 4: no number, only a limit (the forecaster's own chance of this, stated with the estimate: 5%); middle value at least 5.0-fold (0.69 log units) from the limit.
By their numbers in this assay, from the lowest: compounds 2, 3 and 1 (each within the scatter of the next). At a limit, above all of these: compound 4.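

In this assay compound 4 gives > 20000 nM, which is a limit of the assay and not a number. Going by these compounds alone, this is the first change that can be read at a single place, and an at least 4.2-fold higher number from compound 3 to compound 4 (0.63 log units; beyond the scatter) shows that activity in this assay can depend on the group on this sulfur: 1,3-benzothiazol-2-yl in place of 1,3,4-thiadiazol-2-yl costs activity, a loss that the earlier compounds, which offered no single-place step, could not show. Only the lower bound of this step is known, and its full size stays unknown, since the reading ends at a limit: the limit of > 20000 nM in this assay, at which 1 of the 4 values shown sits.

The change adds a six-membered aromatic ring of carbon only and also alters the five-membered ring, so this one step cannot tell which of the two goes with the loss. As far as these compounds go, how a phenyl, a pyridin-2-yl or a benzothiazole ring bearing a carboxylic acid would read on this sulfur, with the rest of compound 3 kept, also remains open.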